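Same atoms, different configuration: from compound 1 to compound 4

The compounds below may be only part of what the source reports. "The series", "measured", "known", "first", "only" and "open" are said of these compounds alone.

Three related compounds have been measured in a physicochemical assay for lipophilicity, using the shake flask method, at pH 7.4; a lower number here means a more polar compound, a higher number a more lipophilic compound. Compound 1 (`CN(C)[C@H]1CC[C@H](Nc2ncnc3[nH]cc([C@H]4CC[C@H](C(N)=O)CC4)c23)CC1`) gives 0, the second highest of the three numbers. Compound 3 (`CN(C)[C@H]1CC[C@H](Nc2ncnc3ccn(C4CCOCC4)c23)CC1`) gives -0.6, a number lower than that of compound 1 by more than the usual scatter. Compound 2 (`CN(C)[C@H]1CC[C@H](Oc2ncnn3ccc([C@H]4CC[C@H](C(N)=O)CC4)c23)CC1`) gives 1, a number higher than that of compound 1, again by more than the scatter.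

Compound 4 (`CN(C)[C@H]1CC[C@H](Nc2ncnc3[nH]cc([C@H]4CC[C@@H](C(N)=O)CC4)c23)CC1`) has not been measured yet. Set against compound 1, it shows (the two compounds have the same atoms and bonds and differ only in configuration as drawn: 2 of 4 stereo elements differ; a stereocentre at a saturated ring carbon is drawn r in compound 1 and s in compound 4; a stereocentre at a saturated ring carbon is drawn r in compound 1 and s in compound 4). The two compounds have the same atoms and bonds and differ only in configuration as drawn, which means that some groups point a different way in space while nothing is added or removed.

Within the data shown here, no two measured compounds differ in configuration alone, and the data therefore offer no direct precedent for this kind of step. The expectation rests on the structural change alone, with the atoms and bonds unchanged, and no shift beyond the scatter is anticipated in either direction. In this assay, the expected change is a number 0.10 log units higher from compound 1 to compound 4 (within the scatter), a step within the scatter. For compound 4 the estimated value is 0.1, with an expected range from -0.3 to 0.5.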

Compound 4, distribution coefficient: 0
Estimate against measurement, compound 4: 0.10 log units above; the measured number falls inside the stated range.
By their numbers in this assay, from the lowest: compound 3; then compounds 1 and 4 (each within the scatter of the next); then compound 2.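

In this assay, this pair gives the series its first direct reading of a change in configuration alone, and the step is no change at the digits printed from compound 1 to compound 4 (within the scatter). The earlier compounds shown here could not show this, since compounds 1, 2 and 3 differ from one another in their atoms and bonds, so their spread of numbers says nothing about spatial arrangement on its own. Here, two stereocentres at saturated ring carbons are drawn differently, no group enters or leaves, and the reading stays within the scatter, which makes the comparison an unusually clean one: the fact that compounds 1 and 4 differ only in the configuration as drawn

From the compounds shown here alone, this is still a single pair, so it remains open whether the same change in configuration would also stay within the scatter if a carboxylic acid or a primary amine took the place of the amide on that ring. Going by these compounds, it is equally open whether the result would carry over to the core of compound 2, which has an ether oxygen where compound 1 has its linking nitrogen.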